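Acetyl on a Lengthened Linker: Expecting Compound 4

This account rests on a few compounds, and the source may have more. Where it says the series, first, only, none or still open, it means among the compounds named here.

Compound 1, `O=C(CCCCC1CCSS1)NCc1cn(CCCOc2ccc3ccc(=O)oc3c2)nn1`, gives 37.2% in a functional assay on PC-12 cells (Rattus norvegicus) for cytotoxicity, read by MTT assay, with stated times of 3 h and 2 h, tested at 1 uM; a higher number here means a stronger effect of the compound at the concentration tested, a lower number a weaker effect.
Compound 2, `CC(=O)c1cc2ccc(OCCCn3cc(CNC(=O)CCCCC4CCSS4)nn3)cc2oc1=O`, gives 35.5% in this assay.
Compound 3, `O=C(CCCCC1CCSS1)NCc1cn(CCCCCOc2ccc3ccc(=O)oc3c2)nn1`, gives 57.2% in this assay.

Compound 1 and compound 2 differ in a single place: acetyl in place of hydrogen on an aromatic carbon. That change produced the step of a number 1.7 percentage points lower from compound 1 to compound 2 (within the scatter), so the two readings cannot be told apart. Compound 3 has a different core; the difference between the two cores is not broken down here. Compound 3 stands highest of the three measured compounds, with compound 1 its nearest neighbour and compound 2 furthest off, both gaps lying beyond the scatter.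

Compound 4, `CC(=O)c1cc2ccc(OCCCCCn3cc(CNC(=O)CCCCC4CCSS4)nn3)cc2oc1=O`, has not yet been measured. It relates to compound 3 as compound 2 relates to compound 1: acetyl in place of hydrogen on an aromatic carbon. The surroundings of the place are described in the same words in both cases, so this is the same change, now made on the core of compound 3. The step expected from compound 3 to compound 4 in this assay is a number 2.2 percentage points lower from compound 3 to compound 4 (within the scatter), set beside the earlier one, because the earlier step was a number 1.7 percentage points lower from compound 1 to compound 2 (within the scatter). Among the measured compounds shown here, only one earlier instance exists, and it sits on a different core, so the expected range is kept fairly wide. Compound 4 is expected to give 55% in this assay, estimated to fall between 44% and 66%.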

Compound 4, a percentage reported as activity, at one concentration (the size of the read-out at that concentration, not a potency): 27.4%
The estimate for compound 4 lay 27.6 percentage points above the measured number, outside the stated range (below it).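

Placing acetyl in place of hydrogen on an aromatic carbon had a much larger effect on the core of compound 3 than on the core of compound 1: in this assay, the change gave a number 29.8 percentage points lower from compound 3 to compound 4 (beyond the scatter), whereas the earlier step gave a number 1.7 percentage points lower from compound 1 to compound 2 (within the scatter). This shows that, in this small series, the size of the step depends on the core carrying the acetyl, so a result on one core cannot simply be transferred to the other: the same change on two cores in this assay, a number 1.7 percentage points lower (within the scatter) from compound 1 to compound 2 and a number 29.8 percentage points lower (beyond the scatter) from compound 3 to compound 4, 28.1 percentage points apart, beyond the scatter of two such steps. It does not show which feature of the two cores produces the difference, why the acetyl has so much more effect on one of them, or whether the same contrast would appear at another concentration, and two pairs of compounds cannot establish a rule for other cores.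

The compounds shown leave open how a different group at the same place, such as a carboxylic acid or an amine, would read on each of the two cores. Among the compounds shown here, they also leave open whether the acetyl step would grow, shrink or hold its size on a core with a longer chain than the one in compound 3.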